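From a Phenol to a Difluorophenyl: an Expected Loss

The compounds below may be only part of what the source reports. "The series", "measured", "known", "first", "only" and "open" are said of these compounds alone.

Of the compounds shown here, three that share one core have been tested in a functional assay on HT-29 cells (Homo sapiens) for cytotoxicity, read by MTT assay, with a stated time of 72 h; on this read-out lower numbers stand for stronger inhibition and higher numbers for weaker inhibition. Compound 1 `CN(C)CCn1cnnc1-c1cc(Oc2ccc(NC(=O)N/N=C/c3cc(C(C)(C)C)cc(C(C)(C)C)c3O)cc2F)ccn1` gives 680 nM. Compound 2 `CN(C)CCn1cnnc1-c1cc(Oc2ccc(NC(=O)N/N=C/c3ccc(O)cc3)cc2F)ccn1` gives 1920 nM. Compound 3 `Cn1ncnc1-c1cc(Oc2ccc(NC(=O)N/N=C/c3ccccc3)cc2F)ccn1` gives 30200 nM. Among these three numbers compound 2 stands second highest: compound 1 sits lower, by a margin beyond the usual scatter, while compound 3 sits higher, also beyond the scatter. Compound 3 differs from compound 2 in more than one place, so its number only shows where it lands, not what one change does.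

Compound 4 `CN(C)CCn1cnnc1-c1cc(Oc2ccc(NC(=O)N/N=C/c3ccc(F)cc3F)cc2F)ccn1` has not yet been measured. It differs from compound 2 in a single place: 2,4-difluorophenyl in place of 4-hydroxyphenyl on a carbon with a double bond to nitrogen. Among the compounds with values here, no step between measured compounds covers this exact change, so the expectation rests on the surrounding numbers alone. Compound 3, which carries a phenyl without a hydroxyl group, shows the highest number, though its other difference clouds the comparison. The step from compound 2 to compound 4 is expected to raise the number, meaning weaker inhibition: a 3.1-fold higher number from compound 2 to compound 4 (0.49 log units; beyond the scatter). Compound 4 is therefore estimated at 6000 nM, with a range from 2000 nM to 20000 nM.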

Compound 4, half-maximal inhibitory concentration: 960 nM
Compound 4: the middle estimate sits 6.3-fold (0.80 log units) above what was measured; the measured number lies below the stated range.
By their numbers in this assay, from the lowest: compounds 1, 4 and 2 (each within the scatter of the next, the first and the last beyond it); then compound 3.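

In this assay, placing 2,4-difluorophenyl where 4-hydroxyphenyl stood gives a 2.0-fold lower number from compound 2 to compound 4 (0.30 log units; within the scatter), so the two groups cannot be told apart at this position on this read-out. The hydroxyl group is therefore not required for a number in this range: the entering group counts 0 hydrogen-bond donors and 0 hydrogen-bond acceptors, yet the result stays within the scatter of compound 2. No measured property of these groups is available to explain this match.

The compounds shown leave open whether a single fluorine would serve as well, as a 4-fluorophenyl on the same core would show. They also leave open how a 4-aminophenyl or a 4-carboxyphenyl, which bring an amine or a carboxylic acid to this place, would compare.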